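The source may hold more compounds than are shown below. What is called first, only, known or untested is meant among the compounds shown, and "the series" means these compounds.

Measured compounds:
- compound 1 `CC(C)(C)Sc1c(CC(C)(C)C(=O)O)n(Cc2ccc(Cl)cc2)c2ccc(CCc3ccc4ccccc4n3)cc12`: in a functional assay (blood) for inhibition, with Homo sapiens as the target (on this read-out lower numbers stand for stronger inhibition and higher numbers for weaker inhibition), compound 1 gives > 3000 nM, which is a limit of the assay and not a number.
- compound 2 `CC(C)(C)Sc1c(CC(C)(C)C(=O)O)n(Cc2ccc(Cl)cc2)c2ccc(OCc3nc4ccccc4s3)cc12`: in this assay compound 2 gives 260 nM.
- compound 3 `C[C@@H](COc1ccc2c(c1)c(SC(C)(C)C)c(CC(C)(C)C(=O)O)n2Cc1ccc(Cl)cc1)c1ccccn1`: in this assay compound 3 gives 280 nM.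

Compound 2 holds the lowest of the two numbers shown, though the gap to its nearest neighbour, a 1.1-fold higher number from compound 2 to compound 3 (0.03 log units; within the scatter), is within the scatter. Compound 4 `CC(C)c1csc(COc2ccc3c(c2)c(SC(C)(C)C)c(CC(C)(C)C(=O)O)n3Cc2ccc(Cl)cc2)n1` differs from compound 2 by 4-isopropyl-1,3-thiazol-2-yl in place of 1,3-benzothiazol-2-yl on a saturated chain carbon bound to an oxygen on an aromatic ring. The step that bears on this is the exchange at the same place, a 1.1-fold higher number from compound 2 to compound 3 (0.03 log units; within the scatter). The large steps of an at least 11-fold lower number from compound 1 to compound 2 (1.06 log units; beyond the scatter) and an at least 10-fold lower number from compound 1 to compound 3 (1.02 log units; beyond the scatter) concern a different part of the structure and carry little weight here. No step beyond the scatter is therefore expected in this assay. Compound 4 is estimated at 300 nM (range 120 nM to 800 nM), the expected step being a 1.2-fold higher number from compound 2 to compound 4 (0.06 log units; within the scatter).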

Compound 4, half-maximal inhibitory concentration: > 3000 nM
Compound 4 gave a limit, no number; the forecaster's own chance of this, stated with the estimate: 5%; at least 10-fold (1.00 log units) between middle value and limit.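

Compound 2 and compound 3 showed only a step within the scatter at this saturated chain carbon bound to an oxygen on an aromatic ring, which made the place look tolerant in this assay. The 4-isopropyl-1,3-thiazol-2-yl group shows otherwise, with an at least 11-fold higher number from compound 2 to compound 4 (1.06 log units; beyond the scatter) and an at least 10-fold higher number from compound 3 to compound 4 (1.02 log units; beyond the scatter). Compound 4 gives a limit, not a number, and its step to compound 1 cannot be read: the limit of > 3000 nM in this assay, at which 2 of the 4 values shown sit.

The compounds shown do not separate the isopropyl group from the departed six-membered aromatic ring of carbon only. A plain 1,3-thiazol-2-yl or a 4-methyl-1,3-thiazol-2-yl at this place would bear on that question.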